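Chlorophenyl Replaces Methylphenyl at the Thiocarbonyl Nitrogen

This account rests on a few compounds, and the source may have more. Where it says the series, first, only, none or still open, it means among the compounds named here.

Compound 1 `COc1cc2c(cc1OC)C(=O)C(CC1CCN(C(=S)Nc3ccccc3C)CC1)C2` was tested in a functional assay on the whole organism (strain Swiss albino) with Mus musculus as the target, with a stated time of 0.5 h (a higher number here means that more compound is needed for the effect, a lower number that less compound is needed), where compound 1 gives 300 mg/kg. Its nearest measured neighbour is compound 3 `COc1cc2c(cc1OC)C(=O)C(CC1CCN(C(=S)Nc3ccccc3Cl)CC1)C2`, which in this assay gives 300 mg/kg; between them, with chloro in place of methyl on an aromatic carbon, no change at the digits printed from compound 1 to compound 3 (within the scatter). A further member of the series, compound 2 `COc1cc2c(cc1OC)C(=O)C(CC1CCN(C(=S)Nc3cccc(C)c3)CC1)C2`, is recorded in this assay only as "not determined" (no result reported), so it contributes no number. On the values shown, compound 1 stands level with compound 3 and nothing in the data puts one ahead of the other.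

The unmeasured compound 4 `COc1cc2c(cc1OC)C(=O)C(CC1CCN(C(=S)Nc3ccc(Cl)cc3)CC1)C2` differs from compound 1 in a single place: 4-chlorophenyl in place of 2-methylphenyl on an amide-type nitrogen. Among the measured compounds shown here, the only measured step that bears on this change is the exchange of methyl for chloro on an aromatic carbon, and there no change at the digits printed from compound 1 to compound 3 (within the scatter). With that step flat and no other comparison available, no shift beyond the scatter in this assay is expected in either direction.

Compound 4 is therefore estimated to give 300 mg/kg, with a range from 150 mg/kg to 600 mg/kg. The step this estimate implies, no change at the digits printed from compound 1 to compound 4 (within the scatter), is expected to stay within the scatter.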

Compound 4, minimum effective dose: 100 mg/kg
Beside the measured number, compound 4's estimate is 3.0-fold (0.48 log units) above it; measured number outside the range, below it.
By their numbers in this assay, from the lowest: compound 4; then compounds 1 and 3 (each within the scatter of the next).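

In this assay, among the compounds shown here, the aryl group on the amide-type nitrogen, whose thiocarbonyl carbon is its other neighbour, turns out not to be a flat position: 4-chlorophenyl in place of 2-methylphenyl gives a 3.0-fold lower number from compound 1 to compound 4 (0.48 log units; beyond the scatter) and is the first change to move the number beyond the scatter. The clearest reading comes from 4-chlorophenyl in place of 2-chlorophenyl, which keeps the same kind of substituent and changes only where it sits on the ring, and this gives a 3.0-fold lower number from compound 3 to compound 4 (0.48 log units; beyond the scatter) even though the exchange of methyl for chloro had given no change at the digits printed from compound 1 to compound 3 (within the scatter) on its own. So among these compounds the placement of the chlorine matters where the identity of the substituent at the 2-position did not, although nothing shown explains this difference.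

On these data alone, it remains open whether a methyl group would bring the same gain at the place the chlorine occupies in compound 4, or whether the gain is tied to chlorine. As far as these compounds go, it is equally open how a methoxy group or a nitrile on that ring would behave, or an open alkyl chain in place of the ring.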